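Exchanging the piperidine on the core for a triazole-bearing amine

The source may report more compounds than this note shows. Statements on the series, on what has been measured and on what is new or still open speak of the compounds shown alone.

Compound 2 `CC(C)(C)[Si](CCc1c(N2CCCCC2)nc2ccc(Cl)cc2c1-c1ccccc1Cl)(c1ccccc1)c1ccccc1` carries a piperidin-1-yl group on the shared core. In an ADME assay on HepG2 2.2.15 cells (Homo sapiens) for cytotoxicity (a higher number here means that more compound is tolerated, a lower number that less compound is tolerated), compound 2 gives > 968000 nM, which is a limit of the assay and not a number. Within the data shown here, the only measured neighbour is compound 1 `CC(C)(C)[Si](CCc1c(OCc2c(F)cccc2F)nc2ccc(Cl)cc2c1-c1ccccc1Cl)(c1ccccc1)c1ccccc1`, in which (2,6-difluorobenzyl)oxy sits on the same aromatic carbon. In this assay compound 1 gives > 1860000 nM, which is also a limit. The step that the two limits leave unreadable from compound 1 to compound 2 stays unreadable, since both values sit at the limit of > 1860000 nM in this assay, at which 1 of the 2 values shown sits, and the limit of > 968000 nM in this assay, at which 1 of the 2 values shown sits, and neither is a number.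

Compound 3 `CC(C)(C)[Si](CCc1c(Nn2nnc3ccccc32)nc2ccc(Cl)cc2c1-c1ccccc1Cl)(c1ccccc1)c1ccccc1` differs from compound 2 by a group of 10 heavy atoms (6 carbon, 4 nitrogen; one five-membered aromatic ring with 3 hetero atoms, one six-membered aromatic ring of carbon only) in place of a group of 6 heavy atoms (5 carbon, 1 nitrogen; one six-membered non-aromatic ring with 1 hetero atom), on an aromatic carbon. Among the measured compounds shown here, no measured step bears on this exchange in a readable way: the two values shown are limits only, so neither the direction nor the size of the step from the piperidin-1-yl group to the new group can be drawn from them. With both measured compounds tolerated up to their limits, the step of an at least 1.2-fold lower number from compound 2 to compound 3 (0.08 log units; that floor lies within the scatter) is expected to be small, and a limit rather than a number is the likelier outcome. Compound 3 is therefore expected to give 800000 nM, within a range from 200000 nM to 3000000 nM.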

Compound 3, half-maximal cytotoxic concentration: > 1250000 nM
Compound 3 gave a limit, no number; the forecaster's own chance of this, stated with the estimate: 70%; middle value at least 1.5-fold (0.19 log units) away from the limit.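

In this assay compound 3 gives > 1250000 nM, which is a limit and not a number. Compound 1, compound 2 and compound 3 all sit at limits, so none of the steps among them can be read. The compounds shown leave open whether, and in which direction, exchanging these groups on the shared core changes how much compound is tolerated.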